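Trimming a Benzyl Ester Down to a Hydroxyl

This account rests on a few compounds, and the source may have more. Where it says the series, first, only, none or still open, it means among the compounds named here.

Measured compounds:
compound 1, `O=C(O)[C@@H]1CCCN1C(=O)CN(c1nc(Cl)nc2[nH]cnc12)C1CC1` — 26%
compound 2, `O=C(CN(c1nc(Cl)nc2[nH]cnc12)C1CC1)N[C@@H](CC(=O)OCc1ccccc1)C(=O)OCc1ccccc1` — 15.6%
compound 3, `NC(=O)CC[C@H](NC(=O)CN(c1nc(Cl)nc2[nH]cnc12)C1CC1)C(=O)O` — 41.1%

Three amides built on a shared core have been tested in a functional assay on the whole organism (Tail, strain ICR) with Mus musculus as the target, in the tail flick test, with a stated time of 90 min, at a dose of 25 umol/kg by the oral route; a lower number here means a weaker effect, a higher number a stronger effect of the compound at the dose given. Compound 3 gives 41.1%, compound 1 gives 26%, and compound 2 gives 15.6%. Compound 2 stands lowest of the three; its gap to compound 1 and its larger gap to compound 3 both lie beyond the scatter of this assay.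

The next compound to be measured is compound 4, `O=C(CN(c1nc(Cl)nc2[nH]cnc12)C1CC1)N[C@@H](CO)C(=O)OCc1ccccc1`. It differs from compound 2 in one place: hydroxy in place of benzyloxycarbonyl on a saturated chain carbon, two bonds along the chain from an amide-type nitrogen and a carbonyl carbon. Among the measured compounds shown here, no step between two measured compounds matches this change, so the size of its effect must be guessed from the spread of the three numbers, which runs from compound 2 up to compound 3.

Since compound 2 sits at the bottom of that spread, an upward step is more likely than a further fall, but a step no larger than the scatter is also plausible. Compound 4 is estimated to give 25% in this assay, within a range of 10% to 45%. This means an expected step of a number 9.4 percentage points higher from compound 2 to compound 4 (within the scatter).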

Compound 4, a percentage reported as activity, at one dose (the size of the read-out at that dose, not a potency): 34.5%
Beside the measured number, compound 4's estimate is 9.5 percentage points below it; measured number inside the range.
By their numbers in this assay, from the lowest: compound 2; then compounds 1, 4 and 3 (each within the scatter of the next, the first and the last beyond it).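

In this assay, replacing benzyloxycarbonyl with hydroxy on a saturated chain carbon, two bonds along the chain from an amide-type nitrogen and a carbonyl carbon, brings a number 18.9 percentage points higher from compound 2 to compound 4 (beyond the scatter). Among the compounds shown here, this is the first change that can be read at a single place, and it shows that the effect at the dose given does not depend on keeping this benzyloxycarbonyl: 10 heavy atoms, including a six-membered aromatic ring, leave and a single oxygen enters, yet the number rises rather than falls. No measurement in hand explains this rise.

The step also leaves open which part of the change carries it, since the ring, the ester and the new hydroxy differ all at once, and compound 4 still holds a second benzyloxycarbonyl whose role at its own place cannot be read from these compounds. Going by these compounds, whether a carboxylic acid, an amine or a longer chain ending in hydroxy on the same saturated chain carbon would move the number further up, or back down, also remains open.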